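This account rests on a few compounds, and the source may have more. Where it says the series, first, only, none or still open, it means among the compounds named here.

Compound 1 `O=C(Nc1cccc([N+](=O)[O-])c1)N1CCN(S(=O)(=O)c2sccc2-c2ccccc2Oc2ccc(O)c(O)c2)CC1` stands highest among the three compounds measured in an assay for binding affinity to Apoptosis regulator Bcl-2 (Homo sapiens), read by fluorescence polarization, with stated times of 30 min and 20 min, tested at 100 uM (a lower number here means less inhibition, a higher number more inhibition at the concentration tested (going by the name of the read-out)), giving 30%. Compound 3 `COc1ccc(Oc2ccccc2-c2ccsc2S(=O)(=O)N2CCN(C(=O)Nc3cccc([N+](=O)[O-])c3)CC2)cc1OC` gives 18% in this assay, and compound 2 `O=C(Nc1cc(C(F)(F)F)cc(C(F)(F)F)c1)N1CCN(S(=O)(=O)c2sccc2-c2ccccc2Oc2ccc(O)c(O)c2)CC1` gives 7%. For the measured compounds named here, the one step described between measured compounds is a number 12 percentage points lower from compound 1 to compound 3 (beyond the scatter), and it concerns the group on the oxygen on the aromatic ring, not the part changed here, so it bears only indirectly on the present question. Compound 4 `O=C(Nc1ccc(F)cc1)N1CCN(S(=O)(=O)c2sccc2-c2ccccc2Oc2ccc(O)c(O)c2)CC1` differs from compound 1 in that (4-fluorophenyl in place of 3-nitrophenyl on an amide-type nitrogen). Going by the values given here, no measured step records a change at this place; what the numbers show is that compound 2, which carries another aryl group on the amide-type nitrogen, sits well below compound 1 in this assay. On that basis a downward step is expected, of a size not fixed by the data, so the estimate for compound 4 is 15%, with a range from 2% to 30%, which corresponds to an expected step of a number 15 percentage points lower from compound 1 to compound 4 (beyond the scatter).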

Compound 4, a percentage reported as inhibition, at one concentration (the size of the read-out at that concentration, not a potency): 33%
For compound 4 the middle estimate is 18 percentage points below the measured one, and the stated range ends below it.
By their numbers in this assay, from the lowest: compound 2; then compound 3; then compounds 1 and 4 (each within the scatter of the next).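

In this assay the exchange of 3-nitrophenyl for 4-fluorophenyl on the amide-type nitrogen gives a number 3 percentage points higher from compound 1 to compound 4 (within the scatter) and so leaves the read-out unchanged within the scatter. For the compounds shown here, a nitro group is therefore not required at this place to keep the read-out of compound 1, yet not every aryl group holds it: compound 2, with two trifluoromethyl groups on its aryl ring, gives 7% against compound 4 at 33%, a value that belongs to the one aryl group swapped on the same core. Nothing given here explains how these groups act on the read-out.

Open, going by these compounds, is what an unsubstituted phenyl, a cyclohexyl ring or a short alkyl chain on this nitrogen would give in this assay. Also open, on these data alone, is whether 4-fluorophenyl would keep its level with 3,4-dimethoxyphenyl, the group of compound 3, in place of 3,4-dihydroxyphenyl.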